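The source may report more compounds than this note shows. Statements on the series, on what has been measured and on what is new or still open speak of the compounds shown alone.

In an ADME assay on HeLa cells (Homo sapiens) for cytotoxicity, read by sulforhodamine B assay, with a stated time of 48 h, tested at 10 uM (on this read-out lower numbers stand for less inhibition and higher numbers for more inhibition at the one concentration tested (going by the name of the read-out)), compound 2 `CCOC(=O)c1cn(C(c2ccccc2)c2cc3cc(Br)ccc3nc2OC)nn1` gives -3.67%, the lowest of the two numbers shown, while compound 1 `CCCCCCCc1cn(C(c2ccccc2)c2cc3cc(Br)ccc3nc2OC)nn1` gives 9.7%. For the measured compounds named here, the one measured step, a number 13.4 percentage points lower from compound 1 to compound 2 (beyond the scatter), was an exchange of heptyl for ethoxycarbonyl on an aromatic carbon. Compound 3 `COc1nc2ccc(Br)cc2cc1C(c1ccccc1)n1cc(CCO)nn1` differs from compound 2 by 2-hydroxyethyl in place of ethoxycarbonyl on an aromatic carbon. Going by the values given here, no measured step exchanges ethoxycarbonyl for 2-hydroxyethyl; the single known step is only a loose guide, and both numbers so far sit near no inhibition. Compound 3 is therefore expected to show a step of a number 6.7 percentage points higher from compound 2 to compound 3 (within the scatter), within the scatter. The estimate for compound 3 is 3%, ranging from -10% to 16%.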

Compound 3, a percentage reported as inhibition, at one concentration (the size of the read-out at that concentration, not a potency): 0.85%
Compound 3: the middle estimate sits 2.2 percentage points above what was measured; the range from low to high includes it.
By their numbers in this assay, from the lowest: compounds 2, 3 and 1 (each within the scatter of the next, the first and the last beyond it).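

Placing 2-hydroxyethyl in place of ethoxycarbonyl on this aromatic carbon gives a number 4.5 percentage points higher from compound 2 to compound 3 (within the scatter) in this assay, so a group with a hydrogen-bond donor does not separate from ethoxycarbonyl here. Set against heptyl, the same position gives a number 8.9 percentage points lower from compound 1 to compound 3 (within the scatter), so compound 3 is separated from neither neighbour, although compound 1 and compound 2 stand apart. Nothing available explains these small differences. Going by these compounds, whether an amine or a carboxylic acid on this carbon would give clear inhibition stays open, as does the effect of a chain longer than heptyl.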